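Inverting one ring stereocentre in a phosphoserine agonist

A few compounds are considered here, and "the series" means these few. Any claim that something is new, unique, unknown or untested is made for them only; others in the source may bear on it.

Of the compounds shown here, three have been tested in an assay on HEK293-A cells with probable G-protein coupled receptor 34 (Mus musculus) as the target, with a stated time of 1.5 h; on this read-out higher numbers stand for larger maximal responses and lower numbers for smaller maximal responses. Compound 1, `CCCCCCCCCCCOc1ccccc1CCC(=O)OC[C@H]1OCC=C[C@@H]1OP(=O)(O)OC[C@H](N)C(=O)O`, gives "not active" (no number reported) in this assay. Compound 2, `Cc1ccc(Oc2cccc(COc3ccccc3CCC(=O)O[C@@H]3CCCO[C@@H]3COP(=O)(O)OC[C@H](N)C(=O)O)c2)cc1`, reaches 1.9 in this assay, while compound 3, `CCCCCCCC/C=C\CCCCCCCC(=O)O[C@@H]1C=CCO[C@@H]1COP(=O)(O)OC[C@H](N)C(=O)O`, gives 0.089 in this assay. Compound 3 thus stands lowest of the two numbers, with compound 2 higher by a gap beyond the usual scatter; compound 1 contributes no number.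

The next compound, compound 4, `CCCCCCCC/C=C\CCCCCCCC(=O)O[C@H]1C=CCO[C@@H]1COP(=O)(O)OC[C@H](N)C(=O)O`, differs from compound 3 in a single way: the two compounds have the same atoms and bonds; at least one stereo element is drawn with a configuration in one of them and without one in the other: 1 of 5 stereo elements differ; a stereocentre at a saturated ring carbon is drawn R in compound 3 and S in compound 4. Nothing else changes.

Going by the values given here, no pair of measured compounds shows what such an inversion does here, so the expected size of the step must rest on compound 3 alone, whose value 0.089 in this assay leaves little room downward. The step from compound 3 to compound 4 in this assay is expected to be small, a number 0.061 higher from compound 3 to compound 4 (within the scatter), probably within the scatter and with an open chance of no response at all. Compound 4 is therefore estimated at 0.15 in this assay, in a range from 0 to 0.6.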

Compound 4, intrinsic activity: the largest response reached, as a fraction of the reference agonist's: "not active" (no number reported)
The entry for compound 4 holds no number; no gap can be computed for the estimate.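

In this assay, going by these compounds alone, compound 4 gives "not active" (no number reported), so no step from compound 3 to compound 4 can be read. The compounds shown leave open how much the stereocentre alone matters to the response, and one caution applies to that comparison: the fact that one of compounds 3 and 4 is drawn with a defined configuration and the other without, at the place where they differ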